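The compounds below may be only part of what the source reports. "The series", "measured", "known", "first", "only" and "open" are said of these compounds alone.

Three compounds sharing one core were examined in an ADME assay on MT4 cells (Homo sapiens) for cytotoxicity, read by spectrophotometry, with a stated time of 5 days; on this read-out lower numbers stand for higher toxicity in this test and higher numbers for lower toxicity in this test. Compound 1 `CONC(=S)N/N=C1\C(=O)N(CN2CCN(c3ccc(Cl)cc3)CC2)c2ccc(C)cc21` gives 300000 nM in this assay. Compound 2 `CONC(=S)N/N=C1\C(=O)N(CN2CCN(c3ccc(OC)cc3)CC2)c2ccc(C)cc21` gives 324000 nM, and compound 3 `CONC(=S)N/N=C1\C(=O)N(CN2CCN(c3ccc(Cl)cc3)CC2)c2ccc(F)cc21` gives 347000 nM. The change from compound 1 to compound 2 is methoxy in place of chloro on an aromatic carbon, and it made a 1.1-fold higher number from compound 1 to compound 2 (0.03 log units; within the scatter). The change from compound 1 to compound 3 is fluoro in place of methyl on an aromatic carbon, and it made a 1.2-fold higher number from compound 1 to compound 3 (0.06 log units; within the scatter). All three values sit within the usual scatter of one another.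

Compound 4 `CONC(=S)N/N=C1\C(=O)N(CN2CCN(c3ccc(OC)cc3)CC2)c2ccc(F)cc21` has not yet been measured in this assay. It differs from compound 3 by methoxy in place of chloro on an aromatic carbon. This is the same change that was made from compound 1 to compound 2, and the two cores differ only by fluoro in place of methyl on an aromatic carbon. Since that step made a 1.1-fold higher number from compound 1 to compound 2 (0.03 log units; within the scatter), compound 4 is expected to show a step of about a 1.1-fold higher number from compound 3 to compound 4 (0.03 log units; within the scatter) from compound 3, within the scatter. On this basis, compound 4 is estimated at 370000 nM in this assay, with a likely range from 250000 nM to 550000 nM.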

Compound 4, half-maximal cytotoxic concentration: 276000 nM
The estimate for compound 4 lay 1.3-fold (0.13 log units) above the measured number; measured number inside the range.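

In this assay, methoxy in place of chloro gave a 1.3-fold lower number from compound 3 to compound 4 (0.10 log units; within the scatter), and fluoro in place of methyl gave a 1.2-fold lower number from compound 2 to compound 4 (0.07 log units; within the scatter). The methoxy-for-chloro change carried from one core to the other without a difference beyond the scatter: the same change on two cores in this assay, a 1.1-fold higher number (0.03 log units; within the scatter) from compound 1 to compound 2 and a 1.3-fold lower number (0.10 log units; within the scatter) from compound 3 to compound 4, 1.4-fold (0.13 log units) apart, within the scatter of two such steps The same holds for fluoro in place of methyl, but with every one of these steps within the scatter, this shows only that no dependence on the core is visible, not that either change has a dependable effect of its own or that it would carry to other cores: the same change on two cores in this assay, a 1.2-fold higher number (0.06 log units; within the scatter) from compound 1 to compound 3 and a 1.2-fold lower number (0.07 log units; within the scatter) from compound 2 to compound 4, 1.4-fold (0.13 log units) apart, within the scatter of two such steps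

The compounds shown leave open how an amine, a carboxylic acid or a longer chain would behave on the same aromatic carbon in place of chloro or methoxy. They also leave open whether any such replacement would give a step beyond the scatter, and whether that step would then carry from one core to the other.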